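Ring swap on the chain carbon: cytotoxicity notes

The source may report more compounds than this note shows. Statements on the series, on what has been measured and on what is new or still open speak of the compounds shown alone.

Measured so far in an ADME assay on MDBK cells (Bos taurus) for cytotoxicity; on this read-out lower numbers stand for higher toxicity in this test and higher numbers for lower toxicity in this test:
- compound 1, `Clc1ccc(Cn2ccc3nc(-c4ccccc4)nc-3c2)cc1`: > 100000 nM, a limit of the test and not a number
- compound 2, `c1ccc(-c2ccc(Cn3ccc4nc(-c5ccccc5)nc-4c3)cc2)cc1`: 18000 nM
- compound 3, `FC(F)(F)Oc1ccc(Cn2ccc3nc(-c4ccccc4)nc-3c2)cc1`: 66000 nM

Compound 1 stands at the edge of what this assay reports: the limit of > 100000 nM in this assay, at which 1 of the 3 values shown sits, so only a floor is known for it. Putting phenyl in place of chloro on an aromatic carbon gives an at least 5.5-fold lower number from compound 1 to compound 2 (0.74 log units; beyond the scatter), and putting trifluoromethoxy in place of chloro on an aromatic carbon gives an at least 1.5-fold lower number from compound 1 to compound 3 (0.18 log units; that floor lies within the scatter). Between the two substituted compounds, a 3.7-fold higher number from compound 2 to compound 3 (0.56 log units; beyond the scatter).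

Compound 4, `c1ccc(-c2nc3ccn(Cc4cccnc4)cc-3n2)cc1`, differs from compound 1 in one place: pyridin-3-yl in place of 4-chlorophenyl on a saturated chain carbon bound to an aromatic nitrogen. No measured step exchanges the ring itself on the saturated chain carbon bound to an aromatic nitrogen; the three steps shown all alter a group on an aromatic carbon. Of the two steps away from compound 1, one gave a lower number and the other lay within the scatter. Going by the values given here, the change to compound 4 has no close counterpart, so the expectation rests on compound 1 alone and is weak. The step is estimated at a number no higher from compound 1 to compound 4 (the limit leaves the size open), that is, none beyond the scatter. Compound 4 is expected to give about 100000 nM in this assay, in the range 35000 nM to 300000 nM, with a fair chance that only a limit is reported again.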

Compound 4, half-maximal cytotoxic concentration: > 100000 nM
Compound 4: only a limit was reported; the forecaster's own chance of this, stated with the estimate: 55%; the middle value sits exactly at the limit.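

Going by these compounds alone, compound 1 and compound 4 both rest at a limit of this assay and not at a number, so no step between them can be read: the limit of > 100000 nM in this assay, at which 2 of the 4 values shown sit. The compounds shown leave open whether pyridin-3-yl in place of 4-chlorophenyl on a saturated chain carbon bound to an aromatic nitrogen changes the number in this assay at all, and in which direction.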